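The source may hold more compounds than are shown below. What is called first, only, known or untested is meant among the compounds shown, and "the series" means these compounds.

The measured compounds in this study:

compound 1, `CCCn1c(-c2ccco2)nc2c(N)ncnc21`, gives 790 nM
compound 2, `CCCn1cnc2c(N)nc(NCc3ccccc3)nc21`, gives 5840 nM
compound 3, `CCCn1cnc2c(N)nc(NCCCc3ccccc3)nc21`, gives 12600 nM

All three were tested in an assay on CHO cells for displacement of a labelled ligand from transmembrane domain-containing protein TMIGD3 (Homo sapiens); a lower number here means a stronger inhibitor, a higher number a weaker inhibitor. Compound 1 returns the lowest number of the set. Compound 2 stands second highest of the three: its nearest neighbour is compound 3, which returns a higher number, a gap beyond the usual scatter; compound 1 lies furthest from it, with a lower number, again beyond the scatter. Since the three differ from one another in more than one place, no single change among them can be tied to a single shift in this assay.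

Compound 4, `CCCn1c(Br)nc2c(N)nc(NCc3ccccc3)nc21`, is the next compound to be tested. It differs from compound 2 in one place only: bromo in place of hydrogen on an aromatic carbon. Among the compounds with values here, no measured pair in this set carries this change, so there is nothing to copy from. Within the data shown here, with no such precedent, the expectation is for a step of modest size, possibly toward a lower number and possibly none beyond the scatter. The step of a 1.5-fold lower number from compound 2 to compound 4 (0.16 log units; within the scatter) is therefore estimated to be small. Compound 4 is expected to give about 4000 nM in this assay, with a plausible range from 1500 nM to 12000 nM.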

Compound 4, inhibition constant: 650 nM
The estimate for compound 4 lay 6.2-fold (0.79 log units) above the measured number; the whole stated range lies above it.
By their numbers in this assay, from the lowest: compounds 4 and 1 (each within the scatter of the next); then compound 2; then compound 3.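

Bromo in place of hydrogen on this aromatic carbon, between two ring nitrogen atoms and next to the ring atom that bears a propyl group, gives a 9.0-fold lower number from compound 2 to compound 4 (0.95 log units; beyond the scatter) in this assay, and this is the first shift in the set that can be tied to one change at one place. The earlier compounds shown here could not show this, as none of them formed a pair differing in a single place; the step now shows that this carbon is not indifferent to what it carries, and that one added bromine atom, with no ring and no hydrogen-bond donors or acceptors, moves the number down rather than up. Nothing measured here bears on why the number moves in this direction.

Going by these compounds, it remains open whether this step belongs to bromo alone or would also appear with chloro, methyl, an amine or a longer chain on the same carbon. On these data alone, it is equally open whether bromo at this place would give a step of similar size on compound 3, whose side chain is longer.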